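Permeability of Three Quinoline-Like Amines in a Membrane Assay

The source may hold more compounds than are shown below. What is called first, only, known or untested is meant among the compounds shown, and "the series" means these compounds.

Measured so far:
- compound 1, `COc1cccc(CNCCCNc2ccnc3cc(-c4ccc(C(C)(C)C)cc4)ccc23)c1O`: 237 10^-6 cm/s
- compound 2, `COc1cccc(CNCCCNc2ccnc3cc(Cc4cccc(C(F)(F)F)c4)ccc23)c1O`: 23 10^-6 cm/s

In an ADME assay for permeability, using PAMPA, with a stated time of 30 min, at pH 7.4 (a lower number here means that the compound crosses the layer more slowly, a higher number that the compound crosses the layer faster), compound 2 gives the lower of the two numbers, and the step of a 10-fold lower number from compound 1 to compound 2 (1.01 log units; beyond the scatter) is large. Compound 3, `COc1cccc(CNCCCNc2ccnc3cc(Oc4cccc(N(C)C)c4)ccc23)c1O`, has not yet been measured; it differs from compound 2 by 3-(dimethylamino)phenoxy in place of 3-(trifluoromethyl)benzyl on an aromatic carbon. Among the compounds with values here, no measured step shows this particular exchange, so the step of a 10-fold lower number from compound 1 to compound 2 (1.01 log units; beyond the scatter) is the only guide, and it concerns a different pair of groups. The expected step in this assay is therefore a 1.3-fold higher number from compound 2 to compound 3 (0.12 log units; within the scatter), with wide uncertainty. Compound 3 is estimated at 30 10^-6 cm/s, within a range of 8 10^-6 cm/s to 110 10^-6 cm/s.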

Compound 3, apparent permeability: 317 10^-6 cm/s
Estimate against measurement, compound 3: 11-fold (1.02 log units) below; measured number above the stated range.
By their numbers in this assay, from the lowest: compound 2; then compounds 1 and 3 (each within the scatter of the next).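

In this assay, within the data shown here, the 3-(dimethylamino)phenoxy group restores a high number where 3-(trifluoromethyl)benzyl gave a low one, with a 14-fold higher number from compound 2 to compound 3 (1.14 log units; beyond the scatter), so this position does not hold only one kind of group. Compared with 4-(tert-butyl)phenyl, the same group gives a 1.3-fold higher number from compound 1 to compound 3 (0.13 log units; within the scatter), so two different groups here leave the number within the scatter. Nothing measured here explains the difference between these groups.

The compounds shown do not separate the part played by the phenoxy oxygen from that of the dimethylamino group. As far as these compounds go, how a carboxylic acid or a primary amine at this position would read also remains open.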